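Swapping a saturated ring for a halogenated aromatic ring

This account rests on a few compounds, and the source may have more. Where it says the series, first, only, none or still open, it means among the compounds named here.

Three compounds in this set share one core, and they differ only in the group attached to that core. Compound 1 `C[C@]1(CN2CCc3nc(-c4ccccc4)ccc3C2)Cn2cc([N+](=O)[O-])nc2O1` is the one for which a result exists. In an ADME assay on Vero cells (Chlorocebus sabaeus) for cytotoxicity, read by MTT assay, with a stated time of 72 h (a higher number here means that more compound is tolerated, a lower number that less compound is tolerated), compound 1 gives > 32 ug/mL, and this is a limit of the assay rather than a number: the limit of > 32 ug/mL in this assay, at which 1 of the 2 values shown sits. Compound 2 `C[C@]1(CN2CCc3nc(C4CCCCC4)ccc3C2)Cn2cc([N+](=O)[O-])nc2O1` was included in the same assay, but in this assay compound 2 gives "not determined" (no result reported), so there is no number to place it on the scale. Compound 3 `C[C@]1(CN2CCc3nc(-c4cccc(Cl)c4F)ccc3C2)Cn2cc([N+](=O)[O-])nc2O1` has not been measured yet. It differs from compound 2 in one place: 3-chloro-2-fluorophenyl in place of cyclohexyl on an aromatic carbon. Within the data shown here, with no measured step in the set to guide the size of this change, and with the single result being a limit, the expectation is that in this assay the change from compound 2 to compound 3 would not move the reading beyond the usual scatter, if a number existed for either. Compound 3 is expected to give about 40 ug/mL, with a range from 16 ug/mL to 100 ug/mL.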

Compound 3, half-maximal cytotoxic concentration: > 32 ug/mL
Compound 3: a limit, no number (the forecaster's own chance of this, stated with the estimate: 65%); the middle value lies beyond the limit too.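

In this assay compound 3 gives > 32 ug/mL as a limit of the assay and not a number. Among these compounds, compound 1 also stands at a limit, so no step from compound 1 to compound 3 can be read: the limit of > 32 ug/mL in this assay, at which 2 of the 3 values shown sit. The compounds shown leave open whether 3-chloro-2-fluorophenyl in place of phenyl changes how much compound the cells tolerate.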